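From vinyl to propoxy in a series held at a limit

The source may report more compounds than this note shows. Statements on the series, on what has been measured and on what is new or still open speak of the compounds shown alone.

Measured so far, each in an ADME assay on BJ cells (Homo sapiens) for cytotoxicity, read by luminescence, with a stated time of 72 h (a lower number here means that less compound is needed, a higher number that more compound is needed for the effect), and each only as a limit:
Compound 1 `CCOC(=O)c1c(-c2cc(F)cc(OC)c2)[nH]c2cc(OC)ccc2c1=O` gives > 21500 nM as a limit
Compound 2 `C=Cc1cccc(-c2[nH]c3cc(OC)ccc3c(=O)c2C(=O)OCC)c1` gives > 21500 nM as a limit
Compound 3 `CCOC(=O)c1c(-c2cccc(OCC)c2)[nH]c2cc(OC)ccc2c1=O` gives > 21500 nM as a limit

Compound 2 has no number of its own in this assay, only > 21500 nM, which is a limit. The whole set stands in the same place, (the limit of > 21500 nM in this assay, at which 3 of the 3 values shown sit), so nothing separates compound 2 from the other two.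

Compound 4 `CCCOc1cccc(-c2[nH]c3cc(OC)ccc3c(=O)c2C(=O)OCC)c1` keeps the shared core and carries propoxy in place of vinyl on an aromatic carbon, meta to a large group propoxy in place of vinyl on an aromatic carbon and is otherwise unchanged.

The closest measured change is a step that the two limits leave unreadable from compound 2 to compound 3, with ethoxy in place of vinyl on an aromatic carbon. Two more steps bear on it more loosely, a step that the two limits leave unreadable from compound 1 to compound 2 and a step that the two limits leave unreadable from compound 1 to compound 3, and neither has a readable size either.

Compound 3, with ethoxy, gives > 21500 nM as a limit, and on that ground no step beyond the scatter is expected in this assay, in either direction. The expected step is a step that the limit leaves unreadable from compound 2 to compound 4 and it is only an estimate. For compound 4 the estimated value is 25000 nM, with an expected range from 13000 nM to 50000 nM, and the assay is expected most likely to report only a limit again.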

Compound 4, half-maximal effective concentration: > 21500 nM
Compound 4 was reported as a limit (the forecaster's own chance of this, stated with the estimate: 85%); the middle value does not contradict the limit.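

In this assay compound 4 gives > 21500 nM, which is a limit, so neither the step to it from compound 2 nor the step to it from compound 3 can be read. Nothing separates the compounds: the limit of > 21500 nM in this assay, at which 4 of the 4 values shown sit. The compounds shown leave open whether vinyl, ethoxy or propoxy makes any difference in this assay.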